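From cyclohexyl to 4-methoxybenzyl on the ring amine nitrogen

This account rests on a few compounds, and the source may have more. Where it says the series, first, only, none or still open, it means among the compounds named here.

Measured so far in a functional assay on SV5A8 cells (Homo sapiens) for cytotoxicity; on this read-out higher numbers stand for weaker inhibition and lower numbers for stronger inhibition:
Compound 1, `Cc1ccc2c(NCc3ccc(NC(=O)C4CCN(C5CCCCC5)CC4)cc3)nc(N(C)C)nc2c1`: > 8320 nM, a limit of the assay.
Compound 2, `Cc1ccc2c(NCc3ccc(NC(=O)C4CCN(Cc5ccccc5)CC4)cc3)nc(N(C)CCN(C)C)nc2c1`: > 8830 nM, a limit of the assay.
Compound 3, `Cc1ccc2c(NCc3ccc(NC(=O)C4CCN(Cc5ccccc5)CC4)cc3)nc(N3CCNC(CCO)C3)nc2c1`: > 8420 nM, a limit of the assay.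

Compound 1 stands at a limit, as the limit of > 8320 nM in this assay, at which 1 of the 3 values shown sits, shows, so it has no number, only a boundary. Compound 2 likewise sits at a limit, (the limit of > 8830 nM in this assay, at which 1 of the 3 values shown sits). Compound 3 sits at a limit as well, (the limit of > 8420 nM in this assay, at which 1 of the 3 values shown sits). For the measured compounds named here, because all three are limits, the one single-point step, a step that the two limits leave unreadable from compound 2 to compound 3, cannot be sized, and no order among the three compounds can be read.

Compound 4, `COc1ccc(CN2CCC(C(=O)Nc3ccc(CNc4nc(N(C)C)nc5cc(C)ccc45)cc3)CC2)cc1`, differs from compound 1 by 4-methoxybenzyl in place of cyclohexyl on an amine nitrogen in a ring. Going by the values given here, no measured step touches that ring nitrogen, so none bears directly on this change. Compound 2 and compound 3 carry a benzyl on the same nitrogen and both sit at limits, so a reading near the limit again seems the likeliest outcome; the expected step that the limit leaves unreadable from compound 1 to compound 4 is therefore small or unreadable. Compound 4 is expected to give about 9000 nM, most likely reported as a limit. Compound 4 is estimated to fall between 3000 nM and 30000 nM.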

Compound 4, half-maximal inhibitory concentration: > 6180 nM
Compound 4 was reported as a limit; the forecaster's own chance of this, stated with the estimate: 80%; the middle value lies beyond the limit too.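

The step between compound 1 and compound 4 cannot be read: both results are limits of the assay, not numbers. The four compounds shown leave open how strongly any of them inhibits in this test, and whether changing the group on the ring nitrogen matters at all.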